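The source may report more compounds than this note shows. Statements on the series, on what has been measured and on what is new or still open speak of the compounds shown alone.

Three compounds built on one shared core have been run so far in a functional assay on HOS cells (Homo sapiens) for antiproliferative activity, read by sulforhodamine B assay (on this read-out higher numbers stand for weaker inhibition of growth and lower numbers for stronger inhibition of growth), and only one of them gives a true number. Compound 2 `CCC[C@H]1O[C@H](COCc2ccccc2)[C@@H](OCc2ccccc2)[C@H](OCc2ccccc2)[C@H]1O` gives 23600 nM in this test. Compound 1 `CC[C@H]1O[C@H](COCc2ccccc2)[C@@H](OCc2ccccc2)[C@H](OCc2ccccc2)[C@H]1O` stands at > 50000 nM as a limit of the assay and not a number. Compound 3 `CCC[C@@H]1O[C@H](COCc2ccccc2)[C@@H](OCc2ccccc2)[C@H](OCc2ccccc2)[C@@H]1O` stands at > 50000 nM as a limit too.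

There is an at least 2.1-fold lower number from compound 1 to compound 2 (0.32 log units; beyond the scatter) when methyl takes the place of hydrogen on a saturated chain carbon, and that size is only a bound because of the limit of > 50000 nM in this assay, at which 2 of the 3 values shown sit, in these data. There is also an at least 2.1-fold higher number from compound 2 to compound 3 (0.32 log units; beyond the scatter) that goes with the fact that compounds 2 and 3 differ only in the configuration as drawn and nothing else.

Compound 4 `O[C@@H]1[C@@H](OCc2ccccc2)[C@H](OCc2ccccc2)[C@@H](COCc2ccccc2)O[C@@H]1CC1CCCCC1` changes a single group of compound 2. The change reads cyclohexyl in place of ethyl on a saturated chain carbon bound to a saturated ring carbon and amounts to cyclohexyl in place of ethyl on a saturated chain carbon bound to a saturated ring carbon. Cut one bond further out, it is propyl to cyclohexylmethyl.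

Only the chain step bears directly on this, since the configuration stays as it is. The expectation therefore rests on compound 2, where an at least 2.1-fold lower number from compound 1 to compound 2 (0.32 log units; beyond the scatter) came with a larger chain. The expected change is a modest 2.1-fold lower number from compound 2 to compound 4 (0.33 log units; beyond the scatter) in the direction of stronger inhibition of growth. Compound 4 is estimated at 11000 nM with an expected range from 3500 nM to 35000 nM in this test.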

Compound 4, concentration for 50% growth inhibition: <= 20700 nM
Compound 4: no number, only a limit; the forecaster's own chance of this, stated with the estimate: 25%; the middle value does not contradict the limit.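

In this assay compound 4 stands at <= 20700 nM, which is a limit of the assay and not a number. Set against compound 2, the change of ethyl to cyclohexyl gives an at least 1.1-fold lower number from compound 2 to compound 4 (0.05 log units; that floor lies within the scatter), so this step alone shows no clear gain, but it does show that a six-membered carbon ring on this saturated chain carbon does not cost growth inhibition. Set against compound 1, the step is an at least 2.4-fold lower number from compound 1 to compound 4 (0.38 log units; beyond the scatter), which is also only a bound but lies clear of the usual scatter, so compound 4 joins compound 2 in doing better than the shorter chain of compound 1.

From the compounds shown here alone, how far cyclohexyl truly differs from ethyl at this place stays open because of a limit: the limit of <= 20700 nM in this assay, at which 1 of the 4 values shown sits. Also open, going by these compounds, is whether a phenyl ring, a piperidine ring or a longer chain such as hexyl on the same carbon would go further, and whether cyclohexyl would keep its effect in the configuration of compound 3.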